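Benzylamino amide in a series held at the limit

The source may hold more compounds than are shown below. What is called first, only, known or untested is meant among the compounds shown, and "the series" means these compounds.

Three amides of the shared core have been read so far in a functional assay on HL-60 cells (Homo sapiens) for antiproliferative activity, read by MTT assay, with a stated time of 24 h (a lower number here means a stronger inhibitor, a higher number a weaker inhibitor), and none gives a number. Compound 1 (`CCCCc1oc2ccccc2c1C(=O)c1ccc(OCC(N)=O)cc1`) gives > 50000 nM here, which is a limit. Compound 2 (`CCCCc1oc2ccccc2c1C(=O)c1ccc(OCC(=O)N2CCCC2)cc1`) gives > 50000 nM here, again a limit. Compound 3 (`CCCCc1oc2ccccc2c1C(=O)c1ccc(OCC(=O)N2CCN(C(=O)OC(C)(C)C)CC2)cc1`) gives > 50000 nM here, also a limit. Compound 2 therefore has no number of its own, and the other two values give it no rank.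

Next comes compound 4 (`CCCCc1oc2ccccc2c1C(=O)c1ccc(OCC(=O)NCc2ccccc2)cc1`), with benzylamino in place of pyrrolidin-1-yl on a carbonyl carbon, and benzylamino in place of pyrrolidin-1-yl on a carbonyl carbon as the counted difference.

Among the measured compounds shown here, the one measured step that bears on this change sits on the same carbonyl carbon. It is a step that the two limits leave unreadable from compound 1 to compound 2 and it offers no size to carry over. For the measured compounds named here, the only other guide is the limit of > 50000 nM in this assay, at which 3 of the 3 values shown sit, and it holds no readable value for any amide so far. No step beyond the scatter can therefore be forecast in this assay and no direction can be given. The expected step is a number no higher from compound 2 to compound 4 (the limit leaves the size open) on this reading. Compound 4 is estimated at 50000 nM with an expected range from 15000 nM to 100000 nM and a limit as the likeliest report.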

Compound 4, half-maximal inhibitory concentration: > 50000 nM
Compound 4: a limit, no number; the forecaster's own chance of this, stated with the estimate: 70%; the middle value lies on the limit itself.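

In this assay compound 4 gives > 50000 nM, which is a limit and not a number. No step can be read between compound 4 and either compound 1 or compound 2. The compounds shown leave open how these amides rank against one another, and the series stands at a single point: the limit of > 50000 nM in this assay, at which 4 of the 4 values shown sit.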